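Notes on the step from compound 3 to compound 4

This account rests on a few compounds, and the source may have more. Where it says the series, first, only, none or still open, it means among the compounds named here.

Measured so far:
compound 1 `CC(C)C[C@@H](c1nc2ccc(C(=O)O)cc2n1C)N1C(=O)CN(c2ccc(Oc3ccccc3)cc2)C1=O` gives 43400 nM in an assay on isolated protein for inhibition of Bile acid receptor (Homo sapiens), read by TR-FRET and LanthaScreen; on this read-out lower numbers stand for stronger inhibition and higher numbers for weaker inhibition
compound 2 `CC(C)C[C@@H](c1nc2ccc(C(=O)O)cc2n1C)N1C(=O)CN(c2ccc(-c3ccccc3)cc2)C1=O` gives 23100 nM in this assay
compound 3 `CC(C)C[C@@H](c1nc2ccc(C(=O)O)cc2n1C)N1C(=O)CN(c2ccc(F)cc2)C1=O` gives 399000 nM in this assay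

Compound 3 stands at the highest number of the three: the step of a 9.2-fold higher number from compound 1 to compound 3 (0.96 log units; beyond the scatter) and the step of a 17-fold higher number from compound 2 to compound 3 (1.24 log units; beyond the scatter) both lie beyond the scatter, while the step of a 1.9-fold lower number from compound 1 to compound 2 (0.27 log units; within the scatter) does not.

Compound 4 `COc1ccc(Oc2ccc(N3CC(=O)N([C@@H](CC(C)C)c4nc5ccc(C(=O)O)cc5n4C)C3=O)cc2)cc1` differs from compound 3 by 4-methoxyphenoxy in place of fluoro on an aromatic carbon. Among the measured compounds shown here, the step bearing most directly on it is a 9.2-fold higher number from compound 1 to compound 3 (0.96 log units; beyond the scatter), run in reverse; the methoxy has no counterpart among the measured compounds. A large downward step is therefore expected in this assay for compound 4, estimated as a 10-fold lower number from compound 3 to compound 4 (1.00 log units; beyond the scatter). The estimate for compound 4 is 40000 nM, range 15000 nM to 120000 nM.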

Compound 4, half-maximal inhibitory concentration: 75300 nM
Compound 4: middle estimate off by 1.9-fold (0.27 log units), on the low side; measured number inside the range.
By their numbers in this assay, from the lowest: compounds 2, 1 and 4 (each within the scatter of the next, the first and the last beyond it); then compound 3.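

In this assay, a large aromatic group at this position again gives a lower number than fluoro (a 5.3-fold lower number from compound 3 to compound 4 (0.72 log units; beyond the scatter)), while methoxy in place of hydrogen on the phenoxy group gives no readable change (a 1.7-fold higher number from compound 1 to compound 4 (0.24 log units; within the scatter)). Unlike phenoxy, 4-methoxyphenoxy separates from phenyl (a 3.3-fold higher number from compound 2 to compound 4 (0.51 log units; beyond the scatter)). No available evidence accounts for these steps.

As far as these compounds go, whether an amine or a carboxylic acid in place of the methoxy would move the number remains open. So does the effect of methoxy on the phenyl group of compound 2.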